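This account rests on a few compounds, and the source may have more. Where it says the series, first, only, none or still open, it means among the compounds named here.

Measured so far:
compound 1, `CC(C)N(Cc1cccc(OCCCCCC(=O)O)c1)C(=O)c1ccc(-c2cccc(OCc3ccccc3)c2)cc1`, in an ADME assay on HepG2 cells (Homo sapiens) for cytotoxicity, read by CellTiter-Glo and resazurin assay, with a stated time of 72 h; a lower number here means that less compound is needed, a higher number that more compound is needed for the effect: > 26000 nM
compound 2, `CCOC(=O)CCCCCOc1cccc(CN(C(=O)c2ccc(-c3cnc(OC)nc3OC)cc2)C(C)C)c1`, in this assay: > 26000 nM

The value of compound 1 in this assay is a limit of the assay, not a number. The value of compound 2 in this assay is likewise a limit of the assay and not a number. Compound 2 therefore cannot be placed in order against compound 1 on what is shown: both sit at the limit of > 26000 nM in this assay, at which 2 of the 2 values shown sit, and no step between two measured compounds is available in this series.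

The next compound, compound 3, `CCOC(=O)CCCCCOc1cccc(CN(C(=O)c2ccc(-c3ccc(Cl)c(Cl)c3)cc2)C(C)C)c1`, differs from compound 2 by 3,4-dichlorophenyl in place of 2,4-dimethoxypyrimidin-5-yl on an aromatic carbon.

Within the data shown here, with no measured step to lean on and both known values at the same limit, the step in this assay is expected to be none beyond the scatter, that is a step that the limit leaves unreadable from compound 2 to compound 3. Compound 3 is estimated at 30000 nM, with a range from 12000 nM to 60000 nM, and the most likely outcome is that only a limit and no number is reported again.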

Compound 3, half-maximal effective concentration: > 26000 nM
Compound 3 was reported as a limit; the forecaster's own chance of this, stated with the estimate: 70%; the middle value is on the limit's open side.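

No new step can be read from compound 2 to compound 3: in this assay each is reported only as a limit of the assay, not as a number, and all the compounds shown share it: the limit of > 26000 nM in this assay, at which 3 of the 3 values shown sit.

Still open, on these data alone, is whether exchanging 2,4-dimethoxypyrimidin-5-yl for 3,4-dichlorophenyl changes the half-maximal effective concentration at all, and by how much.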